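Trifluoromethyl for fluoro on the aryl ring of compound 3

A few compounds are considered here, and "the series" means these few. Any claim that something is new, unique, unknown or untested is made for them only; others in the source may bear on it.

Compound 3 `CSc1c(C#N)c(N)c(C#N)c(C)c1-c1ccc(F)cc1` stands highest of the two numbers in an assay on isolated protein for inhibition of Maltase-glucoamylase (Homo sapiens), tested at 100 uM (on this read-out lower numbers stand for less inhibition and higher numbers for more inhibition at the one concentration tested (going by the name of the read-out)), where compound 3 gives 17.3%. Its nearest neighbour is compound 1 `COc1ccc(-c2c(C#N)c(N)c(C#N)c(SC)c2-c2ccc(F)cc2)cc1`, which in this assay gives 13.4%; the step of a number 3.9 percentage points higher from compound 1 to compound 3 (within the scatter) lies within the scatter. Compound 2 `CSc1c(C#N)c(N)c(C#N)c(C)c1-c1ccccc1F` in this assay gives "not active" (no number reported), with no number reported. Compound 4 `CSc1c(C#N)c(N)c(C#N)c(C)c1-c1ccc(C(F)(F)F)cc1` differs from compound 3 by trifluoromethyl in place of fluoro on an aromatic carbon. Among the compounds with values here, no measured step exchanges one group for another on this aryl ring, so none bears directly on it; the only step on record, from compound 1 to compound 3, was within the scatter. A step within the scatter is therefore expected, a number 0.3 percentage points lower from compound 3 to compound 4 (within the scatter), and compound 4 is estimated at 17% in this assay, between 5% and 30%.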

Compound 4, a percentage reported as inhibition, at one concentration (the size of the read-out at that concentration, not a potency): 22.1%
Beside the measured number, compound 4's estimate is 5.1 percentage points below it; low and high end bracket the measured number.
By their numbers in this assay, from the lowest: compounds 1, 3 and 4 (each within the scatter of the next).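

In this assay, within the data shown here, trifluoromethyl in place of fluoro gives a number 4.8 percentage points higher from compound 3 to compound 4 (within the scatter), the only step with a number on both sides that exchanges one group for another on this aryl ring. At this place, para to a large group, going from 1 heavy atom to 4 leaves the two compounds unseparated by this read-out. No measured property bears on this result.

Still open, on these data alone, is whether an amine or a carboxylic acid at this place would move the read-out beyond the scatter. Also open is how any of these compounds would rank by potency, as the read-out covers a single concentration.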